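The source may report more compounds than this note shows. Statements on the series, on what has been measured and on what is new or still open speak of the compounds shown alone.

Measured in a functional assay, read by spectrophotometry, with a stated time of 5 min; a lower number here means a stronger inhibitor, a higher number a weaker inhibitor:
- compound 1 `CCOc1cc(/C=C/C(=O)C(=Cc2ccc(O)c(OC)c2)C(=O)/C=C/c2ccc(O)c(OCC)c2)ccc1O`: 60500000 nM
- compound 2 `CCOc1cc(/C=C/C(=O)C(=Cc2ccc(O)cc2)C(=O)/C=C/c2ccc(O)c(OCC)c2)ccc1O`: 48000000 nM
- compound 3 `CCOc1cc(/C=C/C(=O)C(=Cc2ccc(O)c(O)c2)C(=O)/C=C/c2ccc(O)c(OCC)c2)ccc1O`: 25200000 nM

Compound 3 sits at the low end of this small set, but not alone there. The two steps that reach it are a 2.4-fold lower number from compound 1 to compound 3 (0.38 log units; beyond the scatter) and a 1.9-fold lower number from compound 2 to compound 3 (0.28 log units; within the scatter). Compound 4 `CCOc1cc(/C=C/C(=O)C(=Cc2ccc(OCC)c(OCC)c2)C(=O)/C=C/c2ccc(O)c(OCC)c2)ccc1O` has 3,4-diethoxyphenyl in place of 3,4-dihydroxyphenyl (3,4-diethoxyphenyl in place of 3,4-dihydroxyphenyl on a double-bonded chain carbon bound to a double-bonded chain carbon). The closest evidence is compound 1, which carries a methyl on one oxygen of that ring, and read backwards, a 2.4-fold lower number from compound 1 to compound 3 (0.38 log units; beyond the scatter) points to a higher number once that hydrogen is replaced. Removing the methoxy group altogether gave a 1.3-fold lower number from compound 1 to compound 2 (0.10 log units; within the scatter). Among the measured compounds shown here, no measured compound has ethyl on this ring, or both oxygens capped, so the size is uncertain. A similar or slightly larger rise is expected, and the expected step is a 2.6-fold higher number from compound 3 to compound 4 (0.41 log units; beyond the scatter). For compound 4 the estimated value is 65000000 nM, with an expected range of 28000000 nM to 150000000 nM.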

Compound 4, half-maximal inhibitory concentration: 61600000 nM
Compound 4: middle estimate off by 1.1-fold (0.02 log units), on the high side; the range from low to high includes it.
By their numbers in this assay, from the lowest: compounds 3, 2, 1 and 4 (each within the scatter of the next, the first and the last beyond it).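

In this assay, replacing 3,4-dihydroxyphenyl with 3,4-diethoxyphenyl gives a 2.4-fold higher number from compound 3 to compound 4 (0.39 log units; beyond the scatter). Compound 4 nevertheless cannot be told apart from the compounds that keep one hydroxy group on this ring, with a 1.3-fold higher number from compound 2 to compound 4 (0.11 log units; within the scatter) and a 1.0-fold higher number from compound 1 to compound 4 (0.01 log units; within the scatter), so capping both oxygens with ethyl adds nothing measurable beyond what those compounds already show. No measurement here explains these steps. Among the compounds shown here, still open is how a ring with only one ethoxy group would read, and what an amine or a carboxylic acid on this ring would give.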